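The source may report more compounds than this note shows. Statements on the series, on what has been measured and on what is new or still open speak of the compounds shown alone.

Compound 1, `COc1cc(/C=C\c2cc(O)c3ccsc3c2)cc(OC)c1OC`, is the point of departure. In a functional assay on cells (Endothelial cell, Bos taurus) for antiproliferative activity (a higher number here means a weaker inhibitor, a lower number a stronger inhibitor), compound 1 gives 87 nM, the lowest of the two numbers actually recorded. Compound 3, `COc1ccc(/C(F)=C\c2cc(OC)c(OC)c(OC)c2)cc1[N+](=O)[O-]`, gives 329000 nM in this assay, a far higher number that lies well beyond the usual scatter. Compound 2, `COc1cc(/C(F)=C/c2cc(O)c3ccoc3c2)cc(OC)c1OC`, is reported in this assay only as a limit, > 1000 nM, not as a number. That limit, (the limit of > 1000 nM in this assay, at which 1 of the 3 values shown sits), shows that this assay stops counting at a ceiling, so weak inhibitors may return no number at all.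

Compound 4, `COc1cc(/C=C/c2cc(O)c3ccsc3c2)cc(OC)c1OC`, is the untested partner of compound 1. The two differ only as the two compounds have the same atoms and bonds and differ only in configuration as drawn: 1 of 1 stereo elements differ; a double bond is drawn Z in compound 1 and E in compound 4. Within the data shown here, no measured pair in this set shows what such a change in configuration alone does, so the expectation rests on the step itself rather than on a measured precedent.

The expectation is that compound 4 will be a clearly weaker inhibitor, with the step from compound 1 estimated as a 57-fold higher number from compound 1 to compound 4 (1.76 log units; beyond the scatter). Compound 4 is thus estimated at 5000 nM, within a range from 500 nM to 50000 nM, and quite possibly returned only as a limit.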

Compound 4, half-maximal inhibitory concentration: 38000 nM
Compound 4: middle estimate off by 7.6-fold (0.88 log units), on the low side; the measured number falls inside the stated range.
By their numbers in this assay, from the lowest: compound 1; then compound 4; then compound 3.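

Turning the double bond from Z to E gives a 440-fold higher number from compound 1 to compound 4 (2.64 log units; beyond the scatter) in this assay, the first measured step in this set and a large one. Nothing enters or leaves along this step, so the whole gap goes with the geometry of that one double bond: the fact that compounds 1 and 4 differ only in the configuration as drawn. Among these compounds, the Z arrangement of compound 1 therefore emerges as a firm requirement for its activity within this pair, something the earlier compounds, which differ in more than one place, could not show.

The compounds shown leave open whether the same switch costs as much when the double bond carries a fluorine, as it does in compound 2. They also leave open how the Z compound would respond if an amine or a carboxylic acid took the place of its hydroxyl group.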